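This account rests on a few compounds, and the source may have more. Where it says the series, first, only, none or still open, it means among the compounds named here.

In a functional assay (trachea) with Rattus norvegicus as the target (on this read-out lower numbers stand for lower potency and higher numbers for higher potency (the scale is a negative logarithm)), compound 1 `CC1(C)C=C(n2ccccc2=O)c2cc(O)ccc2O1` gives 5.31. Compound 2 `CC1(C)C=C(n2ccccc2=O)c2cc(OCC(=O)c3ccccc3)ccc2O1` gives 4.69, and compound 3 `CC1(C)C=C(n2ccccc2=O)c2cc(OC(=O)Nc3ccccc3F)ccc2O1` gives 4.22, the lowest of the three measured numbers. Each replacement of the hydrogen on the oxygen on the aromatic ring cost potency: a number 0.62 log units lower from compound 1 to compound 2 (beyond the scatter), a number 1.09 log units lower from compound 1 to compound 3 (beyond the scatter), and a number 0.47 log units lower from compound 2 to compound 3 (beyond the scatter). Compound 4 `CC1(C)C=C(n2ccccc2=O)c2cc(OS(=O)(=O)F)ccc2O1` differs from compound 3 in one place: fluorosulfonyl in place of (2-fluorophenyl)carbamoyl on an oxygen on an aromatic ring. The entering group is much smaller than the one that leaves, so the change runs partway back toward the unsubstituted oxygen of compound 1, and a modest rise in this assay is expected rather than a further fall. For compound 4 the expected value is 4.8, ranging from 4.2 to 5.4, which would mean a number 0.58 log units higher from compound 3 to compound 4 (beyond the scatter).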

Compound 4, logarithm of the reciprocal of the active concentration, log(1/C): 7.22
Compound 4: middle estimate off by 2.42 log units, on the low side; measured number outside the range, above it.
By their numbers in this assay, from the lowest: compound 3; then compound 2; then compound 1; then compound 4.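

Replacing the hydrogen on this oxygen on an aromatic ring need not cost potency: in this assay, fluorosulfonyl gives a number 1.91 log units higher from compound 1 to compound 4 (beyond the scatter), whereas the two earlier replacements lowered the number. It also stands far from those larger groups, with a number 2.53 log units higher from compound 2 to compound 4 (beyond the scatter) and a number 3.00 log units higher from compound 3 to compound 4 (beyond the scatter), so the group placed here can move this read-out in either direction. Nothing available explains the rise. Still open, from the compounds shown here alone, is whether methyl or methanesulfonyl on this oxygen would also raise the number, or whether fluorosulfonyl is needed.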